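A few compounds are considered here, and "the series" means these few. Any claim that something is new, unique, unknown or untested is made for them only; others in the source may bear on it.

In a functional assay on MT4 cells (Homo sapiens) for inhibition (a lower number here means a stronger inhibitor, a higher number a weaker inhibitor), three compounds sharing one core have been tested, and none gives a readable number. Compound 1 `C=C1[C@@H](O)[C@H](n2cnc3c(Cl)nc(N)nc32)O[C@@H]1CO` carries chloro on an aromatic carbon, and its result is a limit, > 500000 nM. Compound 2 `C=C1[C@@H](O)[C@H](n2cnc3c(N)nc(N)nc32)O[C@@H]1CO` carries amino on that carbon, and its result is also a limit, > 200000 nM. Compound 3 `C=C1[C@@H](O)[C@H](n2cnc3c(O)nc(N)nc32)O[C@@H]1CO` carries hydroxy there, and it too reports only a limit, > 200000 nM. Compound 3 therefore stands at the limit of > 200000 nM in this assay, at which 2 of the 3 values shown sit, with no measured potency to place it against the others.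

Compound 4 `C=C1[C@@H](O)[C@H](n2cnc3c(N(C)C)nc(N)nc32)O[C@@H]1CO` has dimethylamino in place of hydroxy on an aromatic carbon, next to the ring nitrogen: dimethylamino in place of hydroxy on an aromatic carbon.

Three measured steps change the group on this carbon: a step that the two limits leave unreadable from compound 1 to compound 2, a step that the two limits leave unreadable from compound 1 to compound 3 and a step that the two limits leave unreadable from compound 2 to compound 3. None has a size that can be read, but none produced a numerical result either. Compound 2, which also has a nitrogen group on this carbon, remained a limit at > 200000 nM. On that basis, no change beyond the usual scatter is expected in this assay, and no direction can be predicted. The expected step is a number no higher from compound 3 to compound 4 (the limit leaves the size open). A further limit is the likely report for the new compound. For compound 4, the estimated value is 200000 nM, with an expected range from 60000 nM to 500000 nM.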

Compound 4, half-maximal inhibitory concentration: > 500000 nM
Compound 4 was reported as a limit (the forecaster's own chance of this, stated with the estimate: 85%); middle value at least 2.5-fold (0.39 log units) away from the limit.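

In this assay compound 4 also gives only a limit, > 500000 nM. Compound 1, compound 2 and compound 3 are limits as well, so the steps from each of them to compound 4 cannot be read. The compounds shown leave open whether chloro, amino, hydroxy and dimethylamino differ at all in this assay, and whether any group on this carbon gives a measurable potency.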